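From 4-methylphenyl to chloromethyl on the carbonyl

The source may report more compounds than this note shows. Statements on the series, on what has been measured and on what is new or still open speak of the compounds shown alone.

Compound 1 `CC1=NN(C(=O)CN2CCCCC2)C(c2ccccc2O)C1`: 4310 nM
Compound 2 `O=C(c1ccccc1)N1N=C(c2cc3ccccc3oc2=O)CC1c1ccccc1`: 12700 nM
Compound 3 `Cc1ccc(C(=O)N2N=C(c3cc4ccccc4oc3=O)CC2c2ccccc2)cc1`: 31300 nM

In a functional assay on MGC-803 cells (Homo sapiens) for cytotoxicity, read by MTT assay, with a stated time of 48 h (on this read-out lower numbers stand for stronger inhibition and higher numbers for weaker inhibition), compound 3 gives the highest number of the three, at 31300 nM. Compound 4 `O=C(CCl)N1N=C(c2cc3ccccc3oc2=O)CC1c1ccccc1` has not yet been measured. It differs from compound 3 as follows: chloromethyl in place of 4-methylphenyl on a carbonyl carbon. The nearest measured step is a 2.5-fold higher number from compound 2 to compound 3 (0.39 log units; beyond the scatter), but it only adds methyl and keeps the aromatic ring, so it bears on this change indirectly. Compound 1, at 4310 nM, also has no aromatic ring on its carbonyl carbon, though its core differs. A modest fall is therefore expected, with wide uncertainty, and the expected step is a 2.4-fold lower number from compound 3 to compound 4 (0.38 log units; beyond the scatter). Compound 4 is estimated at 13000 nM, within an expected range of 3500 nM to 40000 nM.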

Compound 4, half-maximal inhibitory concentration: 2020 nM
Compound 4: the middle estimate sits 6.4-fold (0.81 log units) above what was measured; the measured number lies below the stated range.
By their numbers in this assay, from the lowest: compound 4; then compound 1; then compound 2; then compound 3.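

In this assay the aromatic ring on the carbonyl carbon proves dispensable: chloromethyl in place of 4-methylphenyl gives a 15-fold lower number from compound 3 to compound 4 (1.19 log units; beyond the scatter) and chloromethyl in place of phenyl gives a 6.3-fold lower number from compound 2 to compound 4 (0.80 log units; beyond the scatter) on the shared core. The earlier methyl step altered only a substituent on that ring, whereas replacing the ring moves the number much further and in the opposite direction. No measured evidence explains this fall.

From the compounds shown here alone, what stays open is whether the chlorine or the loss of the ring accounts for the change. A plain methyl or an aminomethyl group on that carbonyl carbon of the shared core would separate the two.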